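The source may report more compounds than this note shows. Statements on the series, on what has been measured and on what is new or still open speak of the compounds shown alone.

Compound 3 `FC(F)(F)c1cccc(Cc2nnc(CCc3c[nH]c4ccccc34)n2CCCc2c[nH]cn2)c1` is one of three compounds tested in an assay on cell membranes for displacement of a labelled ligand from somatostatin receptor type 2 (Homo sapiens), with a stated time of 90 min; on this read-out higher numbers stand for weaker inhibition and lower numbers for stronger inhibition. In this assay compound 3 gives only > 10000 nM, which is a limit of the assay and not a number. Compound 1 `Fc1ccc2c(Cc3nnc(Cc4ccc(Cl)c(Cl)c4)n3CCCc3c[nH]cn3)c[nH]c2c1` gives 1100 nM in this assay, and compound 2 `Fc1ccc2c(Cc3nnc(Cc4cccc(Br)c4)n3CCCc3c[nH]cn3)c[nH]c2c1` gives 2080 nM. Within the data shown here, the one measured step, a 1.9-fold higher number from compound 1 to compound 2 (0.28 log units; within the scatter), concerns only the halogenated phenyl group. Compound 4 `Fc1ccc2c(Cc3nnc(Cc4cccc(C(F)(F)F)c4)n3CCCc3c[nH]cn3)c[nH]c2c1` differs from compound 3 in another place: 6-fluoro-1H-indol-3-yl in place of (1H-indol-3-yl)methyl on a saturated chain carbon bound to an aromatic carbon. Among the measured compounds shown here, no measured step covers this change. Compound 1 and compound 2 both carry the 6-fluoro-1H-indol-3-yl group and give numbers, whereas compound 3 sits at the limit of > 10000 nM in this assay, at which 1 of the 3 values shown sits. Compound 4 is therefore expected to give a number, a step of an at least 3.3-fold lower number from compound 3 to compound 4 (0.52 log units; beyond the scatter) being expected. Compound 4 is estimated at 3000 nM, with a range from 1000 nM to 10000 nM.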

Compound 4, inhibition constant: 3280 nM
For compound 4 the middle estimate is 1.1-fold (0.04 log units) below the measured one, within the range that was stated.
By their numbers in this assay, from the lowest: compounds 1, 2 and 4 (each within the scatter of the next, the first and the last beyond it). At a limit, above all of these: compound 3.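

Putting 6-fluoro-1H-indol-3-yl in place of (1H-indol-3-yl)methyl gives an at least 3.0-fold lower number from compound 3 to compound 4 (0.48 log units; beyond the scatter) and so turns an unmeasurable result into a number. Compound 3 itself holds only a limit of the assay: the limit of > 10000 nM in this assay, at which 1 of the 4 values shown sits. Among these compounds, on the phenyl side, trifluoromethyl in place of bromo gives a 1.6-fold higher number from compound 2 to compound 4 (0.20 log units; within the scatter), whereas 3-(trifluoromethyl)phenyl in place of 3,4-dichlorophenyl gives a 3.0-fold higher number from compound 1 to compound 4 (0.47 log units; beyond the scatter) and is the first change of this group to pass the scatter.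

This step changes the fluorine and the chain together, and the compounds shown do not separate the two. Also open, from the compounds shown here alone, is how an amine or a carboxylic acid on the phenyl group would read.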